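This account rests on a few compounds, and the source may have more. Where it says the series, first, only, none or still open, it means among the compounds named here.

Measured so far:
Compound 1 `O=C(Nc1ccc(C(F)(F)F)cc1)c1cccc(Nc2ncc(F)c(Nc3ccc(F)cc3)n2)c1`: > 10000 nM (a limit)
Compound 2 `O=C(c1cccc(Nc2ncc(F)c(Nc3ccc(F)cc3)n2)c1)N1CCCCC1`: 13200 nM

For the measured compounds named here, in a functional assay on A549 cells (Homo sapiens) for antiproliferative activity, read by sulforhodamine B assay, with a stated time of 3 days (on this read-out lower numbers stand for stronger inhibition of growth and higher numbers for weaker inhibition of growth), compound 2 gives 13200 nM, the only actual number available so far. Compound 1 is recorded at > 10000 nM, which is a limit of the assay and not a number.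

Compound 3 `COc1cc(NC(=O)c2cccc(Nc3ncc(F)c(Nc4ccc(F)cc4)n3)c2)cc(OC)c1` keeps the core of compound 2 but has (3,5-dimethoxyphenyl)amino in place of piperidin-1-yl on a carbonyl carbon.

Going by the values given here, only one measured step changes this same place: a step that the limit leaves unreadable from compound 1 to compound 2. It therefore gives no size to carry over, and it cannot show a direction either. Compound 1 also has a substituted phenylamino group on that carbonyl carbon, and its result is the limit of > 10000 nM. That offers no sign of a gain in this assay, so no change beyond the usual scatter is expected, in either direction. The expected step is a 1.3-fold lower number from compound 2 to compound 3 (0.12 log units; within the scatter). The estimated value for compound 3 is 10000 nM, with an expected range from 3000 nM to 30000 nM.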

Compound 3, concentration for 50% growth inhibition: 13900 nM
For compound 3 the middle estimate is 1.4-fold (0.14 log units) below the measured one; low and high end bracket the measured number.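

In this assay, the change on this carbonyl carbon now has a readable size: a 1.1-fold higher number from compound 2 to compound 3 (0.02 log units; within the scatter). Piperidin-1-yl, a non-aromatic ring with no hydrogen-bond donors or acceptors, and (3,5-dimethoxyphenyl)amino, a larger group with an aromatic ring, a hydrogen-bond donor and hydrogen-bond acceptors, therefore cannot be told apart in this assay, so these differences between the two groups come with no measurable change in growth inhibition here. The steps that involve compound 1 cannot be read, as its result is a limit and not a number: the limit of > 10000 nM in this assay, at which 1 of the 3 values shown sits.

Still open, from the compounds shown here alone, is whether a group of another kind on this carbonyl carbon, such as a small amine like dimethylamino, a piperazin-1-yl ring with its second nitrogen, or a longer chain ending in a carboxylic acid, would move the number beyond the scatter. All three compounds also share the same core, so the compounds shown say nothing about how changes elsewhere in the molecule would act in this assay.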